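The source may report more compounds than this note shows. Statements on the series, on what has been measured and on what is new or still open speak of the compounds shown alone.

For the measured compounds named here, in a physicochemical assay for solubility (a lower number here means a less soluble compound, a higher number a more soluble compound), compound 1 `CC(C)C(C(=O)NC(N)=O)C(C)C` gives 270 ug/mL and compound 2 `CCCC(C(=O)NC(N)=O)C(C)C` gives 130 ug/mL as the lower of the two numbers so far. Compound 3 `CCCC(CCC)C(=O)NC(N)=O` is still unmeasured and differs from compound 2 by propyl in place of isopropyl on a saturated chain carbon bound to a carbonyl carbon and a saturated chain carbon with propyl in place of isopropyl on a saturated chain carbon bound to a carbonyl carbon and a saturated chain carbon. Going by the values given here, the one measured step is a 2.1-fold lower number from compound 1 to compound 2 (0.32 log units; beyond the scatter) and it is the same swap, a modest one. A similar modest drop in this assay is therefore expected, with a 2.0-fold lower number from compound 2 to compound 3 (0.30 log units; within the scatter) as the estimated step. For compound 3 the estimated value is 65 ug/mL with an expected range from 30 ug/mL to 130 ug/mL for the measurement.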

Compound 3, solubility: 120 ug/mL
Estimate against measurement, compound 3: 1.8-fold (0.27 log units) below, and the stated range covers the measured number.
By their numbers in this assay, from the lowest: compounds 3 and 2 (each within the scatter of the next); then compound 1.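

In this assay, propyl in place of isopropyl on compound 2 gives a 1.1-fold lower number from compound 2 to compound 3 (0.03 log units; within the scatter). The same swap earlier gave a 2.1-fold lower number from compound 1 to compound 2 (0.32 log units; beyond the scatter), so across these two pairs this change on a saturated chain carbon bound to a carbonyl carbon and a saturated chain carbon does not carry one fixed step. Nothing available explains why the two steps read differently. Still open, going by these compounds, is how a longer chain such as butyl, or an amine or a carboxylic acid, would read at this place.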